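The source may report more compounds than this note shows. Statements on the series, on what has been measured and on what is new or still open speak of the compounds shown alone.

Measured in an ADME assay on L02 cells (Homo sapiens) for cytotoxicity, read by MTT assay, with a stated time of 24 h; on this read-out higher numbers stand for weaker inhibition and lower numbers for stronger inhibition:
- Compound 1 `CN1C/C(=C\c2ccc(Br)cc2)C(=O)/C(=C/c2cccc([N+](=O)[O-])c2)C1`: 9850 nM
- Compound 2 `CN1C/C(=C\c2ccc(C(F)(F)F)cc2)C(=O)/C(=C/c2cccc([N+](=O)[O-])c2)C1`: 12400 nM

Compound 2, at 12400 nM, stands level with compound 1 in this assay, within the scatter. Compound 3 `CN1C/C(=C\c2ccc(C#N)cc2)C(=O)/C(=C/c2ccc(C(F)(F)F)cc2)C1` differs from compound 2 by 4-cyanophenyl in place of 3-nitrophenyl on a double-bonded chain carbon bound to a double-bonded ring carbon. For the measured compounds named here, the only measured step, a 1.3-fold higher number from compound 1 to compound 2 (0.10 log units; within the scatter), exchanged bromo for trifluoromethyl and did not touch the 3-nitrophenyl group, so no measurement directly covers this change. No step beyond the scatter is therefore expected, though with wide uncertainty. The estimated change is a 1.0-fold lower number from compound 2 to compound 3 (0.01 log units; within the scatter). For compound 3 the expected value is 12000 nM, with an estimated range of 5000 nM to 30000 nM.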

Compound 3, half-maximal inhibitory concentration: 17200 nM
Beside the measured number, compound 3's estimate is 1.4-fold (0.16 log units) below it, and the stated range covers the measured number.
By their numbers in this assay, from the lowest: compounds 1, 2 and 3 (each within the scatter of the next).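

In this assay the exchange of 3-nitrophenyl for 4-cyanophenyl gives a 1.4-fold higher number from compound 2 to compound 3 (0.14 log units; within the scatter) and is the first step shown on a double-bonded chain carbon bound to a double-bonded ring carbon, since the earlier step exchanged bromo for trifluoromethyl. This place therefore takes a second substituted phenyl group without a step beyond the scatter. Nothing on hand explains the size of this step.

Among the compounds shown, this place carries only these two phenyl groups. As far as these compounds go, whether an amine, a carboxylic acid or a longer chain there would stay within the scatter remains open.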